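The source may hold more compounds than are shown below. What is called first, only, known or untested is meant among the compounds shown, and "the series" means these compounds.

Notes on the series

Among the compounds with values here, compound 1, `Cc1ccc(CN2C(=O)N(Cc3ccccc3)S(=O)(=O)n3cccc32)cc1`, is measured in an ADME assay on MT4 cells (Homo sapiens) for cytotoxicity, read by MTT assay, with a stated time of 5 days (a higher number here means that more compound is tolerated, a lower number that less compound is tolerated), and gives 241000 nM, the only outright number in the set. Compound 2, `O=C1N(Cc2ccccc2Br)c2cccn2S(=O)(=O)N1Cc1cccc(F)c1`, gives in this assay only > 269000 nM, which is a limit of the assay and not a number; this is the limit of > 269000 nM in this assay, at which 1 of the 2 values shown sits. Within the data shown here, with no second number, no measured step within the set can be drawn, so compound 1 simply stands as the one fixed point, with compound 2 sitting at the limit.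

Compound 3, `C=CCN1C(=O)N(Cc2ccccc2)S(=O)(=O)n2cccc21`, is not yet measured in this assay. It differs from compound 1 by vinyl in place of 4-methylphenyl on a saturated chain carbon bound to an amide-type nitrogen in a ring. Among the measured compounds shown here, no measured step of this kind exists in the set, so the expectation rests on compound 1 alone: a change of a 1.0-fold higher number from compound 1 to compound 3 (0.02 log units; within the scatter) is expected, that is none beyond the usual scatter, given that compound 1 gives 241000 nM. Compound 3 is therefore estimated at 250000 nM, within 120000 nM to 500000 nM, with a fair chance that only a limit is reported.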

Compound 3, half-maximal cytotoxic concentration: > 802000 nM
Compound 3 was reported as a limit; the forecaster's own chance of this, stated with the estimate: 40%; at least 3.2-fold (0.50 log units) between middle value and limit.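

In this assay, within the data shown here, vinyl in place of 4-methylphenyl on a saturated chain carbon bound to an amide-type nitrogen in a ring gives an at least 3.3-fold higher number from compound 1 to compound 3 (0.52 log units; beyond the scatter), the first readable step. With the six-membered aromatic ring gone from this place, more compound is tolerated, not less. Compound 3 is reported only as a limit and not a number, so the step sets a floor on the change and not its full size: the limit of > 802000 nM in this assay, at which 1 of the 3 values shown sits.

The compounds shown do not tell whether the step goes with the loss of the aromatic ring or simply with the smaller group, as both change together from compound 1 to compound 3. From the compounds shown here alone, how a cyclohexylmethyl group, which keeps a ring without aromaticity, or a saturated propyl chain would read at this place remains open.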